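Replacing trifluoroethoxy with methylsulfanyl: what compound 3 may give

The source may hold more compounds than are shown below. What is called first, only, known or untested is meant among the compounds shown, and "the series" means these compounds.

Two measured compounds share one core and differ only at an oxygen on an aromatic ring. Compound 1 `CN(C)C(=O)c1cccnc1NCCCN1CCN(c2ccccc2O)CC1` gives 63.1 nM in a functional assay on aorta for antagonist activity at Alpha-1D adrenergic receptor (Rattus norvegicus); on this read-out lower numbers stand for tighter binding and higher numbers for weaker binding. Compound 2 `CN(C)C(=O)c1cccnc1NCCCN1CCN(c2ccccc2OCC(F)(F)F)CC1`, with 2,2,2-trifluoroethyl in place of hydrogen on that oxygen, gives 15.9 nM in this assay; the step is a 4.0-fold lower number from compound 1 to compound 2 (0.60 log units; beyond the scatter). Within the data shown here, compound 2 thus stands with the lowest of the two numbers known so far. Compound 3 `CSc1ccccc1N1CCN(CCCNc2ncccc2C(=O)N(C)C)CC1` has not yet been measured in this assay. It differs from compound 2 as follows: methylsulfanyl in place of 2,2,2-trifluoroethoxy on an aromatic carbon. Among the measured compounds shown here, the only measured step that bears on this change is a 4.0-fold lower number from compound 1 to compound 2 (0.60 log units; beyond the scatter): it shows that what sits on this aromatic carbon moves the number. The change now removes the whole 2,2,2-trifluoroethoxy group and brings in methylsulfanyl, a group present in neither measured compound, so a modest rise in the number, part of the way back toward compound 1, is expected rather than a gain. Compound 3 is therefore estimated to give 30 nM, within 10 nM to 100 nM. As estimated, that would be a step of a 1.9-fold higher number from compound 2 to compound 3 (0.28 log units; within the scatter).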

Compound 3, dissociation constant: 31.6 nM
Estimate against measurement, compound 3: 1.1-fold (0.02 log units) below; the measured number falls inside the stated range.
By their numbers in this assay, from the lowest: compounds 2, 3 and 1 (each within the scatter of the next, the first and the last beyond it).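

In this assay the exchange of 2,2,2-trifluoroethoxy for methylsulfanyl gives a 2.0-fold higher number from compound 2 to compound 3 (0.30 log units; within the scatter) and the exchange of hydroxy for methylsulfanyl gives a 2.0-fold lower number from compound 1 to compound 3 (0.30 log units; within the scatter) on the same aromatic carbon. Compound 3 therefore cannot be separated from either compound 1 or compound 2, even though those two lie beyond the scatter of each other. Among these compounds, the earlier pair showed only that an oxygen-linked group at this position can move the number, whereas compound 3 shows that a sulfur-linked group of 2 heavy atoms gives a number within the scatter of compound 2. No evidence is available to explain these steps.

The compounds shown leave open whether plain ethoxy or methoxy would stand with compound 2 or with compound 1. They also leave open what an amine or a longer sulfur-linked chain would give on this carbon.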